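Ketone side chain on the xanthine core of compound 1

This account rests on a few compounds, and the source may have more. Where it says the series, first, only, none or still open, it means among the compounds named here.

Compound 1, `C=CCn1c(=O)c2[nH]cnc2n(CCC)c1=O`, is a xanthine-type core carrying a propyl chain and an allyl chain. In a functional assay (trachea) with Cavia porcellus as the target (a higher number here means that more compound is needed for the effect, a lower number that less compound is needed), compound 1 gives 1600 nM, the second highest of the three numbers measured. Its nearest neighbour is compound 3, `CCCn1c(=O)n(CCOC)c(=O)c2[nH]cnc21`, which gives 700 nM; the furthest is compound 2, `CCCn1c(=O)n(CCCN(C)C)c(=O)c2[nH]cnc21`, which gives 20500 nM.

The step to the new compound 4, `CCCn1c(=O)n(CCC(C)=O)c(=O)c2[nH]cnc21`, changes the allyl chain: 2-oxopropyl in place of vinyl on a saturated chain carbon bound to an aromatic nitrogen. Two measured steps start from the same vinyl group. Replacing it with a basic amine chain gave a 13-fold higher number from compound 1 to compound 2 (1.11 log units; beyond the scatter), whereas replacing it with a neutral chain bearing one hydrogen-bond acceptor gave a 2.3-fold lower number from compound 1 to compound 3 (0.36 log units; beyond the scatter). The ketone chain of compound 4 resembles the second case more than the first: it carries one hydrogen-bond acceptor and no net charge. The author therefore expects at most a modest step in this assay, most likely a slightly lower number than compound 1, though a result within the scatter would not surprise.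

On that basis compound 4 is estimated to give 1000 nM in this assay, within a range of 350 nM to 3000 nM, which corresponds to an expected step of a 1.6-fold lower number from compound 1 to compound 4 (0.20 log units; within the scatter).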

Compound 4, half-maximal effective concentration: 3500 nM
Beside the measured number, compound 4's estimate is 3.5-fold (0.54 log units) below it; the whole stated range lies below it.
By their numbers in this assay, from the lowest: compound 3; then compound 1; then compound 4; then compound 2.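

In this assay, the change to 2-oxopropyl brings a 2.2-fold higher number from compound 1 to compound 4 (0.34 log units; beyond the scatter) at this place, so the new chain moves the number in the opposite direction from the methoxy-bearing chain of compound 3 when each is compared with the allyl chain. The two oxygen-bearing chains also differ clearly from one another: acetyl in place of methoxy gives a 5.0-fold higher number from compound 3 to compound 4 (0.70 log units; beyond the scatter) and shows that having a hydrogen-bond acceptor on this chain does not by itself fix the number. The chain with the dimethylamino end still gives the highest number of the four. Acetyl in place of (dimethylamino)methyl gives a 5.9-fold lower number from compound 2 to compound 4 (0.77 log units; beyond the scatter). The number of compound 4 thus lies between those of compound 1 and compound 2.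

On these data alone, whether a carboxylic acid, a primary amide or a longer ketone chain at this place would fall nearer to compound 3 or to compound 4 remains open. Nothing available here accounts for the gap between the ketone and methoxy chains.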